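This account rests on a few compounds, and the source may have more. Where it says the series, first, only, none or still open, it means among the compounds named here.

Measured so far in a functional assay on PC-3 cells (Homo sapiens) for cytotoxicity, read by MTT assay, with a stated time of 72 h; a higher number here means a weaker inhibitor, a lower number a stronger inhibitor:
compound 1 `CNC(=O)c1cc(Oc2ccc(C3=NNC(c4ccc(Cl)cc4Cl)C3)cc2)ccn1`: 7300 nM
compound 2 `CNC(=O)c1cc(Oc2ccc(C3=NNC(c4cc(OC)c(OC)c(OC)c4)C3)cc2)ccn1`: 28300 nM
compound 3 `CNC(=O)c1cc(Oc2ccc(C3=NNC(c4ccc(F)cc4Cl)C3)cc2)ccn1`: 24300 nM

Compound 3 stands at 24300 nM, within the scatter of compound 2 at 28300 nM. Compound 3 is separated from compound 1 by a larger gap, a 3.3-fold higher number from compound 1 to compound 3 (0.52 log units; beyond the scatter). Among the measured compounds shown here, of the three numbers, only that of compound 1 stands apart from compound 3.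

Next in the series is compound 4 `CNC(=O)c1cc(Oc2ccc(C3=NNC(c4ccc(OC)cc4)C3)cc2)ccn1`, with 4-methoxyphenyl in place of 2-chloro-4-fluorophenyl on a saturated ring carbon.

For the measured compounds named here, only one measured step bears on this change, and only indirectly. It is a 3.3-fold higher number from compound 1 to compound 3 (0.52 log units; beyond the scatter), a modest shift produced by fluoro in place of chloro on an aromatic carbon of the same aryl group. Going by the values given here, no measured compound carries the 4-methoxyphenyl group itself, and no step isolates the loss of the chloro group or the arrival of a methoxy group. Compound 2, also methoxy-bearing, gives 28300 nM, close to compound 3.

In this assay, no step beyond the scatter is therefore expected, though a modest shift in either direction remains possible. The expected step is a 1.1-fold lower number from compound 3 to compound 4 (0.04 log units; within the scatter). For compound 4 the estimated value is 22000 nM, with an expected range of 9000 nM to 50000 nM.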

Compound 4, half-maximal inhibitory concentration: 7740 nM
For compound 4 the middle estimate is 2.8-fold (0.45 log units) above the measured one; the whole stated range lies above it.
By their numbers in this assay, from the lowest: compounds 1 and 4 (each within the scatter of the next); then compounds 3 and 2 (each within the scatter of the next).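

In this assay the aryl group on the saturated ring carbon responds to more than a halogen exchange: the replacement gives a 3.1-fold lower number from compound 3 to compound 4 (0.50 log units; beyond the scatter) and so shows that an aryl group without chloro or fluoro can match the best value in the series, although compound 2, also free of halogen, stays high at 28300 nM and goes against any rule that removing halogen is enough. Set against the 2,4-dichlorophenyl group, the same 4-methoxyphenyl group gives a 1.1-fold higher number from compound 1 to compound 4 (0.03 log units; within the scatter) and leaves these two groups indistinguishable here, while the 2-chloro-4-fluorophenyl group of compound 3 stands apart from both. No measurement at hand explains why the groups fall in this order.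

Among the compounds shown here, still open is whether the single methoxy group contributes anything by itself, a question that a plain phenyl group at this position would help to settle. On these data alone, it is also open how a dimethylamino group or a carboxylic acid on this aryl ring would compare with the 4-methoxyphenyl group, and whether the ranking of these aryl groups holds outside this one cell line.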